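A few compounds are considered here, and "the series" means these few. Any claim that something is new, unique, unknown or untested is made for them only; others in the source may bear on it.

In an ADME assay on MT4 cells (Homo sapiens) for cytotoxicity, read by MTT assay (a lower number here means that less compound is tolerated, a higher number that more compound is tolerated), compound 2 `Cc1cc(C)cc(S(=O)(=O)c2c(C(=O)NCC(=O)NCc3ccncn3)[nH]c3ccc(Cl)cc23)c1` reaches only a limit of the assay, > 48800 nM. Compound 1 `Cc1cc(C)cc(S(=O)(=O)c2c(C(=O)NCC(=O)NCc3ccncc3)[nH]c3ccc(Cl)cc23)c1` likewise reaches only a limit, > 48900 nM. Within the data shown here, the single step between them, a step that the two limits leave unreadable from compound 1 to compound 2, cannot be read, as both values sit at the limits the limit of > 48800 nM in this assay, at which 1 of the 2 values shown sits, and (the limit of > 48900 nM in this assay, at which 1 of the 2 values shown sits). Compound 3 `Cc1cc(C)cc(S(=O)(=O)c2c(C(=O)NCc3n[nH]c4ccccc34)[nH]c3ccc(Cl)cc23)c1` differs from compound 2 by 1H-indazol-3-yl in place of ((pyrimidin-4-yl)methyl)carbamoyl on a saturated chain carbon bound to an amide-type nitrogen. Among the measured compounds shown here, no measured step bears on this change, so nothing beyond the scatter can be expected in either direction. Compound 3 is therefore expected to sit again at the limit, an estimated 48800 nM with a range from 20000 nM to 120000 nM. This means an expected step of a number no higher from compound 2 to compound 3 (the limit leaves the size open).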

Compound 3, half-maximal cytotoxic concentration: > 50700 nM
Compound 3: no number, only a limit (the forecaster's own chance of this, stated with the estimate: 70%); middle value at least 1.0-fold (0.01 log units) from the limit.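

In this assay compound 3 gives > 50700 nM, a limit of the assay and not a number. Among these compounds, compound 1, compound 2 and compound 3 all sit at limits, so no step among them can be read. The compounds shown leave open whether either change alters the concentration that harms the cells.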